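The compounds below may be only part of what the source reports. "The series", "measured", "known", "first", "only" and "open" are said of these compounds alone.

Values so far in a functional assay on MCF7 cells (Homo sapiens) for inhibition; on this read-out higher numbers stand for weaker inhibition and lower numbers for stronger inhibition:
- Compound 1 `CC/C=C/C=C/[C@@]1(C)SC(O)=CC1=O` gives 16.9 ug/mL
- Compound 2 `CCCCCC[C@@]1(C)SC(=O)C=C1OC` gives 14 ug/mL
- Compound 3 `CCCCCCCC[C@@]1(C)SC(=O)C=C1OC` gives > 50 ug/mL

The entry for compound 3 (> 50 ug/mL) is a limit of the assay and not a number.

Compound 4 `C=CCOC1=CC(=O)S[C@]1(C)CCCCCCCC` differs from compound 3 by vinyl in place of hydrogen on a saturated chain carbon bound to an oxygen on an unsaturated carbon, which turns methoxy into allyloxy. Within the data shown here, no measured step touches this place. Among the measured compounds shown here, the only step available, an at least 3.5-fold higher number from compound 2 to compound 3 (0.55 log units; beyond the scatter), lies elsewhere on the molecule, so it offers only a loose hint that adding carbons need not help. A clear gain in inhibition therefore seems unlikely. The expected step is a step that the limit leaves unreadable from compound 3 to compound 4 ( an estimate, with no real change foreseen ). For compound 4 the estimated value is 60 ug/mL, with an expected range from 25 ug/mL to 150 ug/mL ( quite possibly only a limit again ).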

Compound 4, half-maximal inhibitory concentration: > 50 ug/mL
Compound 4 gave a limit, no number; the forecaster's own chance of this, stated with the estimate: 65%; the middle value is on the limit's open side.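

Compound 3 and compound 4 both give only a limit, not a number, in this assay, so no step between them can be read: the limit of > 50 ug/mL in this assay, at which 2 of the 4 values shown sit.

The compounds shown leave open whether allyloxy in place of methoxy changes inhibition at all.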